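The source may report more compounds than this note shows. Statements on the series, on what has been measured and on what is new or still open speak of the compounds shown alone.

In a functional assay on HT-29 cells (Homo sapiens) for inhibition, read by MTT assay (a lower number here means a stronger inhibitor, a higher number a weaker inhibitor), compound 1 (`COc1ccc(/C=C2\c3cc(OC)c(OC)c(OC)c3CC[C@@H]2O)cc1F`) gives 3 nM and compound 2 (`COc1ccc(/C=C2\c3cc(OC)c(OC)c(OC)c3CC[C@@H]2O)cc1C#N`) gives 5 nM, and the change between them, a 1.7-fold higher number from compound 1 to compound 2 (0.22 log units; within the scatter), is small. Compound 3 (`COc1ccc(/C=C2\c3cc(OC)c(OC)c(OC)c3CC[C@@H]2O)cc1N`) has the highest number of the three at 160 nM, and the steps to it are both large: a 53-fold higher number from compound 1 to compound 3 (1.73 log units; beyond the scatter) and a 32-fold higher number from compound 2 to compound 3 (1.51 log units; beyond the scatter). Compound 4 (`COc1ccc(/C=C2\c3cc(OC)c(OC)c(OC)c3CC[C@@H]2O)cc1O`) differs from it by hydroxy in place of amino on an aromatic carbon, with hydroxy in place of amino on an aromatic carbon. Among the compounds with values here, no measured compound carries hydroxy, so these two steps are the only guide, and they show only that the amino compound stands apart from the fluoro and cyano compounds. A partial return towards them is expected, an estimated 6.4-fold lower number from compound 3 to compound 4 (0.81 log units; beyond the scatter) in this assay. For compound 4 the estimate is 25 nM, with an expected range of 4 nM to 150 nM.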

Compound 4, half-maximal inhibitory concentration: 260 nM
The estimate for compound 4 lay 10-fold (1.02 log units) below the measured number, outside the stated range (above it).
By their numbers in this assay, from the lowest: compounds 1 and 2 (each within the scatter of the next); then compounds 3 and 4 (each within the scatter of the next).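

In this assay, hydroxy in place of amino, ortho to a methoxy group, gives a result much like amino itself: a 1.6-fold higher number from compound 3 to compound 4 (0.21 log units; within the scatter). Hydroxy also stands well apart from the other two groups, with a 52-fold higher number from compound 2 to compound 4 (1.72 log units; beyond the scatter) and an 87-fold higher number from compound 1 to compound 4 (1.94 log units; beyond the scatter). Amino is not a lone exception. The compounds now fall into two pairs, fluoro with cyano and amino with hydroxy, though no measurement shown gives a reason for this split. Where methyl or chloro would fall remains open, as does what separates the two pairs.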